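This account rests on a few compounds, and the source may have more. Where it says the series, first, only, none or still open, it means among the compounds named here.

Measured so far in a functional assay on MCF7 cells (Homo sapiens) for cytotoxicity; on this read-out higher numbers stand for weaker inhibition and lower numbers for stronger inhibition:

Compound 1 `C=C/C=C\[C@H](C)[C@H](OC(N)=O)[C@@H](C)[C@H](O)[C@@H](C)C/C(C)=C\[C@H](C)[C@@H](O)[C@@H](C)/C=C\CCc1ccc(Oc2ccccc2)cc1` gives 4000 nM
Compound 2 `C=C/C=C\[C@H](C)[C@H](OC(N)=O)[C@@H](C)[C@H](O)[C@@H](C)C/C(C)=C\[C@H](C)[C@@H](O)[C@@H](C)/C=C\CCc1cccc(F)c1` gives 370 nM
Compound 3 `C=C/C=C\[C@H](C)[C@H](OC(N)=O)[C@@H](C)[C@H](O)[C@@H](C)C/C(C)=C\[C@H](C)[C@@H](O)[C@@H](C)/C=C\CCc1sccc1C` gives 370 nM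

Compound 3 (370 nM) stands level with compound 2, and the two share the lowest number of the three. Compound 1 has a much higher number (4000 nM). Compound 4 `C=C/C=C\[C@H](C)[C@H](OC(N)=O)[C@@H](C)[C@H](O)[C@@H](C)C/C(C)=C\[C@H](C)[C@@H](O)[C@@H](C)/C=C\CCc1cc(O)cc(O)c1` keeps the shared core but carries 3,5-dihydroxyphenyl in place of 3-methylthiophen-2-yl on a saturated chain carbon, two bonds along the chain from a double-bonded chain carbon.

Among the measured compounds shown here, the one measured step at this place shows no change at the digits printed from compound 2 to compound 3 (within the scatter) when one ring end group replaces another. That might suggest the end group can be exchanged freely, but compound 1 goes against this idea, with its much higher number (4000 nM). For the measured compounds named here, no measured compound has hydroxy groups on its end ring, which leaves this change without direct precedent. Since the one clear departure among these compounds is upward, a moderate move in that direction seems more likely than a downward one. The expected step in this assay is a 2.0-fold higher number from compound 3 to compound 4 (0.31 log units; beyond the scatter) towards a higher number, although a step within the scatter remains possible. The estimate for compound 4 is 750 nM (expected range 250 nM to 3000 nM).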

Compound 4, half-maximal inhibitory concentration: 160 nM
Estimate against measurement, compound 4: 4.7-fold (0.67 log units) above, and the stated range ends above it.
By their numbers in this assay, from the lowest: compound 4; then compounds 2 and 3 (each within the scatter of the next); then compound 1.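

Replacing 3-methylthiophen-2-yl with 3,5-dihydroxyphenyl on this saturated chain carbon gives a 2.3-fold lower number from compound 3 to compound 4 (0.36 log units; beyond the scatter) in this assay, and replacing 3-fluorophenyl with the same group gives a 2.3-fold lower number from compound 2 to compound 4 (0.36 log units; beyond the scatter). The earlier compounds had shown only a level pair, compound 2 and compound 3, and one much higher number, with compound 1 at 4000 nM, whereas compound 4 shows that the number can also fall at this position, if only modestly, and that an end ring with hydrogen-bond donors can give the lowest number of the four. Nothing available here accounts for this drop.

The compounds shown leave open whether both hydroxy groups are needed, as 3-hydroxyphenyl would test one hydroxy group alone and 3,5-dimethoxyphenyl would test the same ring with the hydroxy hydrogens replaced by methyl groups. Among the compounds shown here, they also leave open how an end ring carrying an amine or a carboxylic acid would read in this assay, so the single result for compound 4 does not yet define a trend for this position.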